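This account rests on a few compounds, and the source may have more. Where it says the series, first, only, none or still open, it means among the compounds named here.

Measured so far:
- Compound 1 `COc1cc(NC(=O)NNc2cc(-c3ccccc3)c3cnn(C)c3n2)cc(Cl)n1`: 31300 nM
- Compound 2 `COc1ccc(-c2cc(NNC(=O)Nc3cc(Cl)nc(OC(C)C)c3)nc3c2cnn3C)cc1`: 39800 nM
- Compound 3 `Cn1ncc2c(-c3ccccc3)cc(NNC(=O)Nc3cc(Cl)nc(Cl)c3)nc21`: 6240 nM

All three values come from a functional assay on HCT-116 cells (Homo sapiens) for cytotoxicity, read by MTT assay, with a stated time of 48 h, in the presence of a further agent that is not named here; a lower number here means that less compound is needed, a higher number that more compound is needed for the effect. Going by the values given here, compound 1 stands within the scatter of compound 2, and the one measured single-place step shows a 5.0-fold lower number from compound 1 to compound 3 (0.70 log units; beyond the scatter). Compound 4 `COc1cc(NC(=O)NNc2cc(-c3ccc(F)cc3)c3cnn(C)c3n2)cc(Cl)n1` carries fluoro in place of hydrogen on an aromatic carbon of compound 1, phenyl to 4-fluorophenyl: fluoro in place of hydrogen on an aromatic carbon. That measured step swaps chloro for methoxy at a different place, so it gives no direct size for this change. No step beyond the scatter is therefore expected, and no direction can be favoured. The expected change is a 1.1-fold lower number from compound 1 to compound 4 (0.03 log units; within the scatter). For compound 4 the estimated value is 29000 nM, with an expected range from 13000 nM to 60000 nM.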

Compound 4, half-maximal effective concentration: 75300 nM
Estimate against measurement, compound 4: 2.6-fold (0.41 log units) below; measured number above the stated range.
By their numbers in this assay, from the lowest: compound 3; then compounds 1, 2 and 4 (each within the scatter of the next, the first and the last beyond it).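

In this assay, going by these compounds alone, phenyl to 4-fluorophenyl gives a 2.4-fold higher number from compound 1 to compound 4 (0.38 log units; beyond the scatter), the first measured step at this ring, since the earlier step placed chloro in place of methoxy at a different place. It shows that this aromatic carbon is not indifferent to a single fluoro, and that on the core of compound 1 the number rises with it. Nothing available bears on the reason for this step.

The compounds shown leave open whether the rise is particular to fluoro. An amine or a trifluoromethyl group on the same carbon could move the number either way.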